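Open chain for cyclopentyl: working notes on compound 4

A few compounds are considered here, and "the series" means these few. Any claim that something is new, unique, unknown or untested is made for them only; others in the source may bear on it.

Three compounds of the series have numbers in a functional assay on HEp-2 cells (Homo sapiens) for inhibition, read by MTT assay, with a stated time of 72 h; a lower number here means a stronger inhibitor, a higher number a weaker inhibitor. Compound 1 `O=C1C=C[C@@H](OC2CCCC2)O[C@@H]1CO` gives 8000 nM and compound 2 `O=C1C=C[C@@H](OC2CCCCC2)O[C@@H]1CO` gives 7500 nM, so these two lie within the scatter of each other. Compound 3 `C=CCO[C@@H]1C=CC(=O)[C@@H](CO)O1` gives 26100 nM, which leaves compound 1 together with compound 2 at the lower end of the three numbers.

Compound 4 `C#CCCO[C@@H]1C=CC(=O)[C@@H](CO)O1` has not yet been measured. Its difference from compound 1 is but-3-yn-1-yl in place of cyclopentyl on an oxygen on a saturated carbon.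

Among the compounds with values here, one measured step bears on this change: a 3.3-fold higher number from compound 1 to compound 3 (0.51 log units; beyond the scatter). There, allyl takes the place of cyclopentyl at the same kind of position, and the step is modest but beyond the scatter. Within the data shown here, in both cases a group with a ring gives way to an open chain, although this rests on a single pair and the triple bond has no measured precedent. A step in the same direction is therefore expected in this assay, of similar or somewhat smaller size. The expected step is a 2.5-fold higher number from compound 1 to compound 4 (0.40 log units; beyond the scatter). Compound 4 is estimated at 20000 nM, with an expected range of 9000 nM to 42000 nM.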

Compound 4, half-maximal inhibitory concentration: 7100 nM
For compound 4 the middle estimate is 2.8-fold (0.45 log units) above the measured one, and the stated range ends above it.
By their numbers in this assay, from the lowest: compounds 4, 2 and 1 (each within the scatter of the next); then compound 3.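

In this assay, the exchange of cyclopentyl for but-3-yn-1-yl gives a 1.1-fold lower number from compound 1 to compound 4 (0.05 log units; within the scatter), so at this oxygen on a saturated carbon the loss of the ring does not by itself raise the number, and the earlier allyl step cannot stand as a general rule for open chains. The open chains also differ from each other: propargyl in place of vinyl on a saturated chain carbon bound to an oxygen on a saturated carbon gives a 3.7-fold lower number from compound 3 to compound 4 (0.57 log units; beyond the scatter), so compound 3 and compound 4, both without a ring, do not share one level. No measurement at hand accounts for this difference between the two chains.

Compound 3 and compound 4 differ in both the triple bond and the chain, so the compounds shown do not separate these two changes; a plain butyl chain at this oxygen would bear directly on that question. From the compounds shown here alone, it also remains open how a chain carrying an amine or a carboxylic acid would read in this assay.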